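The source may report more compounds than this note shows. Statements on the series, on what has been measured and on what is new or still open speak of the compounds shown alone.

In a functional assay on DU-145 cells (Homo sapiens) for antiproliferative activity, read by WST assay, with a stated time of 72 h (on this read-out higher numbers stand for an effect only at larger amounts of compound and lower numbers for an effect already at smaller amounts), compound 3 `CCCCCCCC/C=C\c1c(C)c(/C=C\CCCCCCCC)c2[n+](c1C)CCC2` gives 1 uM. Compound 2 `CCCCCCCCCCc1c(C)c(CCCCCCCCCC)c2[n+](c1C)CCC2` gives 1.3 uM, and these two numbers lie within the usual scatter of repeated measurements, so the assay does not separate them. Compound 1 `CCCCCCCC/C=C\c1c(C)nc(C)c(/C=C\CCCCCCCC)c1C` is reported in this assay as > 30 uM, which is a limit of the assay and not a number.

Compound 4 `CCCCCCCC/C=C\c1c(C)c(/C=C/CCCCCCCC)c(C)[n+]2c1CCC2` has not yet been measured, and it is a very close relative of compound 3. The structural change is small: the two compounds have the same atoms and bonds and differ only in configuration as drawn: 1 of 2 stereo elements differ; a double bond is drawn Z in compound 3 and E in compound 4. Nothing leaves and nothing enters, so the two compounds are the same on paper except for how that one double bond is drawn.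

For the measured compounds named here, no measured pair in this small set differs in this way, so the data give no direct guide to what such a change does. Going by the values given here, the expectation therefore rests on compound 3 at 1 uM and compound 2 at 1.3 uM, the only two numbers available. With so slight a change, no shift beyond the scatter is expected in either direction, and the estimated step is a 1.2-fold higher number from compound 3 to compound 4 (0.08 log units; within the scatter). For compound 4 the estimated value is 1.2 uM, with an expected range from 0.5 uM to 3 uM.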

Compound 4, concentration for half-maximal effect: 0.8 uM
Beside the measured number, compound 4's estimate is 1.5-fold (0.18 log units) above it, within the range that was stated.
By their numbers in this assay, from the lowest: compounds 4, 3 and 2 (each within the scatter of the next). At a limit, above all of these: compound 1.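

In this assay, turning one double bond from Z to E gives a 1.3-fold lower number from compound 3 to compound 4 (0.10 log units; within the scatter), so the assay does not tell the two geometries apart. For the compounds shown here, none of the earlier compounds could show this, as no measured pair among them differed in configuration alone, and this pair now shows that redrawing this one double bond, with the other left as Z, leaves the antiproliferative number within the usual scatter of repeated measurements. The comparison can be read directly, as a single feature varies and every atom and bond stays the same: the fact that compounds 3 and 4 differ only in the configuration as drawn

As far as these compounds go, compound 4 still keeps one Z double bond, so the form with both double bonds drawn E remains open, as does the effect of a longer chain, or of an amine or a carboxylic acid in place of one chain, on the same shared core. All of these numbers also come from a single cell line and a single read-out, so whether the Z and E forms stay this close in other cells remains an open question.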